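This account rests on a few compounds, and the source may have more. Where it says the series, first, only, none or still open, it means among the compounds named here.

Compound 3 `N#C[Se]c1ccc(NC(=O)Oc2ccccc2)cc1` belongs to a small series built on one shared core, in which only the group on the oxygen next to the carbonyl varies. In a functional assay on CCRF-CEM cells (Homo sapiens) for cytotoxicity, read by MTT assay, with a stated time of 72 h (on this read-out higher numbers stand for lower toxicity in this test and lower numbers for higher toxicity in this test), compound 3 gives 73200 nM. Among the three measured members it stands second highest, though all three sit close together: compound 1 `CCCOC(=O)Nc1ccc([Se]C#N)cc1` gives 68800 nM in this assay, and compound 2 `N#C[Se]c1ccc(NC(=O)OCc2ccccc2)cc1` gives 73700 nM. The steps already seen are small, a 1.1-fold higher number from compound 1 to compound 2 (0.03 log units; within the scatter) and a 1.1-fold higher number from compound 1 to compound 3 (0.03 log units; within the scatter), so neither a phenyl on the saturated chain carbon nor a phenyl directly on the oxygen moved the number out of the scatter.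

Compound 4 `CC(C)COC(=O)Nc1ccc([Se]C#N)cc1` has not yet been tested. Its change from compound 3 is isobutyl in place of phenyl on an oxygen next to a carbonyl group. The step from compound 1 to compound 3 bears most directly on it, being the same exchange run in reverse with a different chain, and that step stayed within the scatter; the step from compound 1 to compound 2 agrees. He therefore expects no step beyond the scatter, a 1.0-fold lower number from compound 3 to compound 4 (0.02 log units; within the scatter). His estimate for compound 4 in this assay is 70000 nM, with a range from 35000 nM to 140000 nM.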

Compound 4, concentration lethal to 50% of the cells: 68700 nM
The estimate for compound 4 lay 1.0-fold (0.01 log units) above the measured number, within the range that was stated.
By their numbers in this assay, from the lowest: compounds 4, 1, 3 and 2 (each within the scatter of the next).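

In this assay the ring on this oxygen can give way to an open branched chain with little consequence: isobutyl in place of phenyl gives a 1.1-fold lower number from compound 3 to compound 4 (0.03 log units; within the scatter) and, set against the phenyl on the saturated chain carbon, the branched chain gives a 1.1-fold lower number from compound 2 to compound 4 (0.03 log units; within the scatter) so a ring is not needed here to hold the number. Branching itself also leaves the number within the scatter, as methyl in place of hydrogen on the chain gives a 1.0-fold lower number from compound 1 to compound 4 (0.00 log units; within the scatter) and the linear and branched chains cannot be told apart. Nothing available here accounts for how closely these compounds agree.

Going by these compounds, all four groups on this oxygen consist of carbon and hydrogen only, so an amine, a carboxylic acid or a much longer chain at this place remains open. The shared core does not vary among these compounds, so its part in the number also remains open.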